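Hydroxypyrrolidine for Hydroxymethylpyrrolidine on a Shared Amide

This account rests on a few compounds, and the source may have more. Where it says the series, first, only, none or still open, it means among the compounds named here.

Three amides share one core: compound 1 `COc1ccc(C#Cc2ccc(C(=O)N3CCC[C@@H](O)C3)c(F)c2)cc1`, compound 2 `COc1ccc(C#Cc2ccc(C(=O)N3CCC(CO)C3)cc2)cc1` and compound 3 `COc1ccc(C#Cc2ccc(C(=O)N3CC[C@@H](O)C3)cc2)cc1`. In a functional assay on HEK293 cells for negative allosteric modulation of metabotropic glutamate receptor 2 (Rattus norvegicus), read by calcium flux, with a stated time of 2.5 min (a higher number here means a weaker inhibitor, a lower number a stronger inhibitor), compound 1 gives only a limit, > 30000 nM. In this assay compound 2 likewise gives only a limit, > 30000 nM. In this assay compound 3 also reaches only a limit, > 30000 nM. Compound 2 thus stands at the limit where every value here sits, (the limit of > 30000 nM in this assay, at which 3 of the 3 values shown sit). Among the measured compounds shown here, the single step between measured neighbours, a step that the two limits leave unreadable from compound 2 to compound 3, is left unreadable by the two limits.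

The unmeasured compound 4 `COc1ccc(C#Cc2ccc(C(=O)N3CC[C@H](O)C3)cc2)cc1` differs from compound 2 in one place: 3-hydroxypyrrolidin-1-yl in place of 3-(hydroxymethyl)pyrrolidin-1-yl on a carbonyl carbon. For the measured compounds named here, compound 3 carries the same group in the other configuration, so the only step bearing on this change, a step that the two limits leave unreadable from compound 2 to compound 3, yields no size. Going by the values given here, no measured step reads beyond the scatter, and nothing here points to a gain. Compound 4 is expected to remain at or near the limit. The step that the limit leaves unreadable from compound 2 to compound 4 is estimated to be none that could be read. Compound 4 is estimated at 40000 nM, within a range from 10000 nM to 150000 nM.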

Compound 4, half-maximal inhibitory concentration: > 30000 nM
Compound 4 ended at the assay's limit; the forecaster's own chance of this, stated with the estimate: 85%; the middle value is on the limit's open side.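

No step among compound 2, compound 3 and compound 4 can be read, as all of them sit at one limit: the limit of > 30000 nM in this assay, at which 4 of the 4 values shown sit.

The compounds shown leave open whether 3-hydroxypyrrolidin-1-yl and 3-(hydroxymethyl)pyrrolidin-1-yl, or the two configurations of compound 3 and compound 4, differ at all in this assay.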